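Chloro-to-methyl exchange on the amide aryl ring

The source may report more compounds than this note shows. Statements on the series, on what has been measured and on what is new or still open speak of the compounds shown alone.

Measured compounds:
compound 1 `O=C(/C=C/c1cccc(NC(=O)c2ccccc2Cl)c1)c1nc2ccccc2[nH]1` 3690 nM
compound 2 `O=C(Nc1cccc(/C=C/C(=O)c2nc3ccccc3[nH]2)c1)c1cccc(Cl)c1` 3370 nM
compound 3 `Cc1ccccc1C(=O)Nc1cccc(/C=C/C(=O)c2nc3ccccc3[nH]2)c1` 8290 nM

All three share one core and differ only in the aryl group on the amide carbonyl. In a functional assay on 143B cells (Homo sapiens) for antiproliferative activity, read by MTT assay, with a stated time of 48 h (on this read-out lower numbers stand for stronger inhibition and higher numbers for weaker inhibition), compound 2 gives the lowest number of the three, but its gap to compound 1 is small: a 1.1-fold lower number from compound 1 to compound 2 (0.04 log units; within the scatter). Compound 3 sits apart from both: a 2.5-fold higher number from compound 2 to compound 3 (0.39 log units; beyond the scatter) and a 2.2-fold higher number from compound 1 to compound 3 (0.35 log units; beyond the scatter).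

Compound 4 `Cc1cccc(C(=O)Nc2cccc(/C=C/C(=O)c3nc4ccccc4[nH]3)c2)c1` has not yet been measured. Its difference from compound 2: methyl in place of chloro on an aromatic carbon. Among the compounds with values here, only one measured step exchanges chloro for methyl on this ring, the one from compound 1 to compound 3, where the exchange sits on a different carbon of the ring and the number rose by a 2.2-fold higher number from compound 1 to compound 3 (0.35 log units; beyond the scatter). The step from compound 2 to compound 3 combines that exchange with a shift of position, so it bears less directly. Within the data shown here, no measured pair shows the exchange with the group kept meta to the large group.

On that basis a modest rise in this assay is expected for compound 4, estimated as a 1.9-fold higher number from compound 2 to compound 4 (0.29 log units; within the scatter). The expected value for compound 4 is 6500 nM, with a range from 3000 nM to 14000 nM.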

Compound 4, half-maximal inhibitory concentration: 4880 nM
For compound 4 the middle estimate is 1.3-fold (0.12 log units) above the measured one, within the range that was stated.
By their numbers in this assay, from the lowest: compounds 2, 1, 4 and 3 (each within the scatter of the next, the first and the last beyond it).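

In this assay the exchange of chloro for methyl, kept meta to a large group, can now be read directly (a 1.4-fold higher number from compound 2 to compound 4 (0.16 log units; within the scatter)), and going from 3-chlorophenyl to 3-methylphenyl leaves the number within the scatter. Moving the methyl from the 2-methylphenyl to the 3-methylphenyl arrangement stays within the scatter as well (a 1.7-fold lower number from compound 3 to compound 4 (0.23 log units; within the scatter)), as does the comparison across the two chloro and methyl aryl groups (a 1.3-fold higher number from compound 1 to compound 4 (0.12 log units; within the scatter)), so the new compound does not separate from any of the earlier three, although compound 3 remains beyond the scatter from compound 1 and compound 2. The chloro-to-methyl exchange therefore cannot be told apart between the two ring carbons: the same change on two cores in this assay, a 2.2-fold higher number (0.35 log units; beyond the scatter) from compound 1 to compound 3 and a 1.4-fold higher number (0.16 log units; within the scatter) from compound 2 to compound 4, 1.6-fold (0.19 log units) apart, within the scatter of two such steps.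

Going by these compounds, whether a methoxy group, an amine or a carboxylic acid on this aryl ring would take the number beyond the scatter remains open. All four compounds are read in this assay alone, which leaves open whether these small steps hold on other cells.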